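Swapping the Sulfonyl Aryl Group: Bromo to Nitro

This account rests on a few compounds, and the source may have more. Where it says the series, first, only, none or still open, it means among the compounds named here.

Within the data shown here, compound 2 `CN(c1ccc2[nH]c(-c3n[nH]c4ccccc34)cc2n1)S(=O)(=O)c1ccc(Br)cc1` gives 11500 nM in a functional assay on SMMC-7721 cells (Homo sapiens) for antiproliferative activity, read by MTT assay, with a stated time of 72 h (on this read-out higher numbers stand for weaker inhibition and lower numbers for stronger inhibition), the lowest of the two numbers measured so far, though compound 1 `Cc1ccc(S(=O)(=O)N(C)c2ccc3[nH]c(-c4n[nH]c5ccccc45)cc3n2)cc1` at 16300 nM lies within the scatter of it, as the step of a 1.4-fold lower number from compound 1 to compound 2 (0.15 log units; within the scatter) shows. Compound 3 `CN(c1ccc2[nH]c(-c3n[nH]c4ccccc34)cc2n1)S(=O)(=O)c1cccc([N+](=O)[O-])c1` carries 3-nitrophenyl in place of 4-bromophenyl on a sulfonyl sulfur. Among the measured compounds shown here, the one measured step altered a substituent on the same aryl ring and stayed within the scatter, so the bromo-to-nitro exchange is expected to shift the read-out little. Compound 3 is therefore estimated at 12000 nM, between 5000 nM and 30000 nM. The expected step is a 1.0-fold higher number from compound 2 to compound 3 (0.02 log units; within the scatter).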

Compound 3, half-maximal inhibitory concentration: 5070 nM
Compound 3: middle estimate off by 2.4-fold (0.37 log units), on the high side, and the stated range covers the measured number.
By their numbers in this assay, from the lowest: compound 3; then compounds 2 and 1 (each within the scatter of the next).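

In this assay the aryl group on a sulfonyl sulfur now moves the read-out beyond the scatter, which the exchange of bromo for methyl did not do: 3-nitrophenyl brings a 2.3-fold lower number from compound 2 to compound 3 (0.36 log units; beyond the scatter) and a 3.2-fold lower number from compound 1 to compound 3 (0.51 log units; beyond the scatter) as modest steps. This change replaces both the substituent and its ring position in one step, so the two effects cannot be separated. No measurement shown bears on why the number falls. From the compounds shown here alone, whether 4-nitrophenyl or 3-bromophenyl would give a similar number remains open. So does the outcome of an amine or a carboxylic acid on this ring.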